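The compounds below may be only part of what the source reports. "The series", "measured", "known", "first", "only" and "open" are said of these compounds alone.

Working notes on the series. The shared core is that of compound 1 `Cc1c(O)ccc2c1[C@H](Cn1cc(-c3ccc(F)cc3)nn1)[C@@]13CC(=O)[C@@](C)(CC[C@@H]21)C3`; in a functional assay on A549 cells (Homo sapiens) for cytotoxicity, read by MTT assay, with a stated time of 4 days (a higher number here means a weaker inhibitor, a lower number a stronger inhibitor), compound 1 gives only a limit, > 20000 nM, and no number. Compound 2 `C=C1C(=O)[C@]23C[C@@]1(O)CC[C@H]2c1ccc(O)c(C)c1[C@@H]3Cn1cc(-c2ccc(C(F)(F)F)cc2)nn1` gives 1110 nM in this assay, the lower of the two numbers recorded so far. Compound 3 `C=C1C(=O)[C@]23C[C@@]1(O)CC[C@H]2c1ccc(OS(=O)(=O)c2ccc(C)cc2)c(C)c1[C@@H]3Cn1cc(-c2ccc(F)cc2)nn1` gives 1950 nM in this assay, a value that sits within the scatter of compound 2, so no order is drawn between those two. Compound 4 `C=C1C(=O)[C@]23C[C@@]1(O)CC[C@H]2c1ccc(O)c(C)c1[C@@H]3Cn1cc(-c2ccccn2)nn1` is not yet measured. It differs from compound 2 in one place: pyridin-2-yl in place of 4-(trifluoromethyl)phenyl on an aromatic carbon. Among the compounds with values here, no measured pair in the set isolates a change at this place, so the step from compound 2 to compound 4 in this assay has no precedent among the numbers at hand. A small shift toward a higher number, not far beyond the scatter, is expected: a 2.3-fold higher number from compound 2 to compound 4 (0.35 log units; beyond the scatter). For compound 4 the estimate in this assay is 2500 nM, with an expected range from 900 nM to 7000 nM.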

Compound 4, half-maximal inhibitory concentration: 1570 nM
Compound 4: the middle estimate sits 1.6-fold (0.20 log units) above what was measured; the measured number falls inside the stated range.
By their numbers in this assay, from the lowest: compounds 2, 4 and 3 (each within the scatter of the next). At a limit, above all of these: compound 1.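

Within the data shown here, the pair of compound 2 and compound 4 is the first to isolate a change on this aromatic carbon of the five-membered aromatic ring with 3 nitrogen: pyridin-2-yl in place of 4-(trifluoromethyl)phenyl gives, in this assay, a 1.4-fold higher number from compound 2 to compound 4 (0.15 log units; within the scatter). This position therefore accepts the exchange of a carbon-only aromatic ring for one with a ring nitrogen and a hydrogen-bond acceptor, and with fewer heavy atoms, without the two compounds being told apart in this read-out. Nothing at hand gives a cause for this step.

Still open, from the compounds shown here alone, is whether a group of another kind on this carbon, such as a simple amine, a carboxylic acid or a longer alkyl chain, would stay within the scatter of compound 2. Equally open, going by these compounds, is whether a pyridine joined through another ring carbon would do so.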